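From 2-cyclopropylpyrimidin-5-yl to 6-ethoxypyridin-3-yl: clearance outlook

The source may hold more compounds than are shown below. What is called first, only, known or untested is meant among the compounds shown, and "the series" means these compounds.

Compound 1 `CCc1ncc(-c2nc(C(F)(F)F)sc2N2CCN(C(=O)Cn3nc(C)nc3C)[C@H](C)C2)cn1` gives 43 mL.min-1.g-1 in a toxicity assay on microsomes from liver (Homo sapiens) for metabolic stability, read by LC-MS, using NADPH, tested at 1 uM; on this read-out lower numbers stand for slow clearance and higher numbers for fast clearance. Compound 2 `Cc1nc(C)n(CC(=O)N2CCN(c3sc(C(F)(F)F)nc3-c3cnc(C4CC4)nc3)C[C@H]2C)n1` gives < 10 mL.min-1.g-1 in this assay, and this is a limit of the assay, not a number. For the measured compounds named here, the one measured step is an at least 4.3-fold lower number from compound 1 to compound 2 (0.63 log units; beyond the scatter), with cyclopropyl in place of ethyl on an aromatic carbon, and it lies beyond the scatter.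

Compound 3 `CCOc1ccc(-c2nc(C(F)(F)F)sc2N2CCN(C(=O)Cn3nc(C)nc3C)[C@H](C)C2)cn1` has not been measured. Its change is 6-ethoxypyridin-3-yl in place of 2-cyclopropylpyrimidin-5-yl on an aromatic carbon. Going by the values given here, no measured step replaces this whole group, so the evidence is indirect. Among the compounds with values here, compound 3 no longer carries the cyclopropyl, and the only data on that group are the step of an at least 4.3-fold lower number from compound 1 to compound 2 (0.63 log units; beyond the scatter), so part of that gap is expected to reopen. A move to a higher number in this assay is therefore expected, estimated as an at least 2.2-fold higher number from compound 2 to compound 3 (0.34 log units; beyond the scatter). For compound 3 the estimated value is 22 mL.min-1.g-1, with an expected range of 10 mL.min-1.g-1 to 50 mL.min-1.g-1.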

Compound 3, intrinsic clearance in microsomes: 66 mL.min-1.g-1
Compound 3: middle estimate off by 3.0-fold (0.48 log units), on the low side, and the stated range ends below it.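

In this assay, 6-ethoxypyridin-3-yl in place of 2-cyclopropylpyrimidin-5-yl gives an at least 6.6-fold higher number from compound 2 to compound 3 (0.81 log units; beyond the scatter), so the low clearance seen with the cyclopropyl group is not retained with this replacement on the aromatic carbon of the five-membered ring. Against the ethyl analogue, the change gives a 1.5-fold higher number from compound 1 to compound 3 (0.19 log units; within the scatter), which leaves 6-ethoxypyridin-3-yl and 2-ethylpyrimidin-5-yl unseparated in this assay and leaves 2-cyclopropylpyrimidin-5-yl as the only one of the three groups with a step beyond the scatter from both others. The value of compound 2 is a limit of the assay and not a number, so the size of both steps involving it is a bound only: the limit of < 10 mL.min-1.g-1 in this assay, at which 1 of the 3 values shown sits.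

On these data alone, the ring and its substituent change together from compound 2 to compound 3, so it remains open whether the cyclopropyl group alone accounts for the low number, and a 6-cyclopropylpyridin-3-yl group or a 2-ethoxypyrimidin-5-yl group at this position would separate the two. Also open, as far as these compounds go, is whether other substituents on this ring, such as a methoxy, an isopropyl or a cyclobutyl group, would read like cyclopropyl or like ethyl in this assay.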